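Replacing Thiophen-3-yl with 1-Methyl-1H-pyrazol-5-yl

The compounds below may be only part of what the source reports. "The series", "measured", "known", "first", "only" and "open" are said of these compounds alone.

Three compounds share one core and differ only in the ring on a carbonyl carbon. In a functional assay on OVCAR-8 cells (Homo sapiens) for inhibition, read by colorimetric assay and sulforhodamine B assay, with a stated time of 48 h (a lower number here means a stronger inhibitor of growth, a higher number a weaker inhibitor of growth), compound 3 `CCCCCCCCCCCC[C@@H](O)[C@H]1CC[C@H]([C@H](O)CCCCCCCCCCNC(=O)c2ccsc2)O1`, which carries thiophen-3-yl, gives 1910 nM, the lowest of the three numbers. Compound 1 `CCCCCCCCCCCC[C@@H](O)[C@H]1CC[C@H]([C@H](O)CCCCCCCCCCNC(=O)c2ccco2)O1`, with furan-2-yl, gives 100000 nM, and compound 2 `CCCCCCCCCCCC[C@@H](O)[C@H]1CC[C@H]([C@H](O)CCCCCCCCCCNC(=O)c2cncs2)O1`, with 1,3-thiazol-5-yl, gives 100000 nM.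

Compound 4 `CCCCCCCCCCCC[C@@H](O)[C@H]1CC[C@H]([C@H](O)CCCCCCCCCCNC(=O)c2ccnn2C)O1` has 1-methyl-1H-pyrazol-5-yl in place of thiophen-3-yl on a carbonyl carbon.

Going by the values given here, three measured steps bear on this change. Exchanging the two weaker rings made no difference: no change at the digits printed from compound 1 to compound 2 (within the scatter). Bringing in thiophen-3-yl, however, gave a large gain each time: a 52-fold lower number from compound 1 to compound 3 (1.72 log units; beyond the scatter), and a 52-fold lower number from compound 2 to compound 3 (1.72 log units; beyond the scatter). So far, thiophen-3-yl is the only ring tested that gives growth inhibition at a clearly lower concentration, though three compounds make a thin basis, and none of them carries a pyrazole. Leaving thiophen-3-yl therefore points towards a higher number in this assay, meaning weaker inhibition, possibly as far as the value of compound 2 at 100000 nM. The expected change is a 10-fold higher number from compound 3 to compound 4 (1.02 log units; beyond the scatter). The estimate for compound 4 is 20000 nM, with an expected range of 2500 nM to 100000 nM.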

Compound 4, concentration for 50% growth inhibition: 30900 nM
Beside the measured number, compound 4's estimate is 1.5-fold (0.19 log units) below it, and the stated range covers the measured number.
By their numbers in this assay, from the lowest: compound 3; then compound 4; then compounds 1 and 2 (each within the scatter of the next).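

In this assay, the ring on this carbonyl carbon now gives three levels of growth inhibition, not two. Moving to 1-methyl-1H-pyrazol-5-yl loses much of what thiophen-3-yl provides (a 16-fold higher number from compound 3 to compound 4 (1.21 log units; beyond the scatter)), yet the same ring still improves on the 1,3-thiazol-5-yl of compound 2 (a 3.2-fold lower number from compound 2 to compound 4 (0.51 log units; beyond the scatter)) and on the furan-2-yl of compound 1 (a 3.2-fold lower number from compound 1 to compound 4 (0.51 log units; beyond the scatter)). The position therefore does not split simply into thiophen-3-yl and everything else: the weaker rings can be told apart, although the gain from either of the two poorest rings to the pyrazole is modest, and compound 3 remains clearly the lowest of the four.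

On these data alone, how a phenyl ring, a thiophen-2-yl ring or a pyridin-3-yl ring would fare on this carbonyl carbon stays open, as does the part played by the methyl group on the pyrazole, which a pyrazole with hydrogen in its place would test. Nothing measured here explains why these rings differ in this way.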